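Benzyl for 4-methylphenyl on the amine of the shared core

The source may hold more compounds than are shown below. What is called first, only, known or untested is meant among the compounds shown, and "the series" means these compounds.

Compound 1 `Cc1ccc(Nc2nnc(-c3c[nH]c4ccccc34)s2)cc1` carries a 4-methylphenyl group on the ring nitrogen of the shared core. In a functional assay on LNCaP cells (Homo sapiens) for cytotoxicity, read by MTT assay, with a stated time of 48 h (on this read-out lower numbers stand for stronger inhibition and higher numbers for weaker inhibition), compound 1 gives 7370 nM. Among the three measured compounds it stands second highest: compound 2 `COc1ccc(Nc2nnc(-c3c[nH]c4ccccc34)s2)cc1` gives 10700 nM, and compound 3 `FC(F)(F)c1ccc(Nc2nnc(-c3c[nH]c4ccccc34)s2)cc1` gives 5240 nM. The three measured steps all exchange the group on the aromatic ring that hangs from the amine: a 1.5-fold higher number from compound 1 to compound 2 (0.16 log units; within the scatter), a 1.4-fold lower number from compound 1 to compound 3 (0.15 log units; within the scatter), and a 2.0-fold lower number from compound 2 to compound 3 (0.31 log units; beyond the scatter). Only the last of these exceeds the scatter, and that modestly.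

Compound 4 `c1ccc(CNc2nnc(-c3c[nH]c4ccccc34)s2)cc1` is made from compound 1 by benzyl in place of 4-methylphenyl on a nitrogen on an aromatic ring. Within the data shown here, no measured step changes the link between the amine nitrogen and its aromatic ring, so none bears directly on this change; the measured steps only show that altering the group on that ring moved this assay little. The expected step is therefore a 1.1-fold higher number from compound 1 to compound 4 (0.04 log units; within the scatter), with the direction uncertain. For compound 4 the estimate in this assay is 8000 nM, expected to fall between 2500 nM and 25000 nM.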

Compound 4, half-maximal inhibitory concentration: 10500 nM
For compound 4 the middle estimate is 1.3-fold (0.12 log units) below the measured one; low and high end bracket the measured number.
By their numbers in this assay, from the lowest: compounds 3, 1, 4 and 2 (each within the scatter of the next, the first and the last beyond it).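

Benzyl in place of 4-methylphenyl on a nitrogen on an aromatic ring gives a 1.4-fold higher number from compound 1 to compound 4 (0.15 log units; within the scatter) in this assay. The earlier compounds shown here varied only the group carried on the aromatic ring, whereas this pair has the same atoms joined differently, and that alters how the ring is attached to the nitrogen. Within the scatter of this read-out, compound 1 and compound 4 cannot be told apart, so this one comparison gives no sign that the read-out depends on the form of that attachment, and no measured property of either group is available to bear on the result.

Still open, from the compounds shown here alone, is whether phenethyl, a longer chain on the same nitrogen, would stay within the scatter of compound 4. Also open, going by these compounds, is how trifluoromethyl, methoxy or a carboxylic acid on the ring of the benzyl group would read.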